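Swapping indole for 4-methoxyphenyl on a shared core

The compounds below may be only part of what the source reports. "The series", "measured", "known", "first", "only" and "open" are said of these compounds alone.

Of the compounds shown here, three with one shared core have been tested in a functional assay on DU-145 cells (Homo sapiens) for inhibition, read by trypan blue exclusion, with a stated time of 96 h; on this read-out lower numbers stand for stronger inhibition of growth and higher numbers for weaker inhibition of growth. Compound 1 `Cc1ccc(S/C(=C/c2ccc(Br)cc2)C(=O)c2ccc(Cl)cc2)cc1` gives 25000 nM, compound 2 `Cc1ccc(S/C(=C/c2ccc(Oc3ccccc3)cc2)C(=O)c2ccc(Cl)cc2)cc1` gives 10000 nM, and compound 3 `Cc1ccc(S/C(=C/c2c[nH]c3ccccc23)C(=O)c2ccc(Cl)cc2)cc1` gives 10000 nM. Compound 3 is level with compound 2, and together they hold the lowest number of the three.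

Compound 4 `COc1ccc(/C=C(/Sc2ccc(C)cc2)C(=O)c2ccc(Cl)cc2)cc1` has not yet been measured. It differs from compound 3 at one place: 4-methoxyphenyl in place of 1H-indol-3-yl on a double-bonded chain carbon bound to a double-bonded chain carbon. Here 4-methoxyphenyl stands in place of 1H-indol-3-yl, on a double-bonded chain carbon bound to a double-bonded chain carbon.

Going by the values given here, two measured steps bear on this. Phenoxy in place of bromo gave a 2.5-fold lower number from compound 1 to compound 2 (0.40 log units; beyond the scatter), and 1H-indol-3-yl in place of 4-bromophenyl gave a 2.5-fold lower number from compound 1 to compound 3 (0.40 log units; beyond the scatter). Both are modest, so a large jump seems unlikely. Compound 4 has a 4-substituted phenyl group, as compound 1 does at 25000 nM, so a small move toward a higher number is expected. The estimated step is a 1.5-fold higher number from compound 3 to compound 4 (0.18 log units; within the scatter). For compound 4 the estimate is 15000 nM, with an expected range from 6000 nM to 35000 nM.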

Compound 4, concentration for 50% growth inhibition: 1000 nM
The estimate for compound 4 lay 15-fold (1.18 log units) above the measured number; measured number outside the range, below it.
By their numbers in this assay, from the lowest: compound 4; then compounds 2 and 3 (each within the scatter of the next); then compound 1.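

In this assay, going by these compounds alone, the group on this double-bonded chain carbon turns out to matter more than the earlier compounds suggested: 4-methoxyphenyl in place of 1H-indol-3-yl gives a 10-fold lower number from compound 3 to compound 4 (1.00 log units; beyond the scatter), a larger move than the earlier 2.5-fold lower number from compound 1 to compound 3 (0.40 log units; beyond the scatter). The group carried by the phenyl ring also counts, not just the presence of a substituted phenyl ring, since methyl in place of phenyl on the oxygen gives a 10-fold lower number from compound 2 to compound 4 (1.00 log units; beyond the scatter) and methoxy in place of bromo gives a 25-fold lower number from compound 1 to compound 4 (1.40 log units; beyond the scatter). Nothing available here explains these differences.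

Still open, on these data alone, is whether a hydroxyl or a dimethylamino group in place of methoxy would keep compound 4's level. A longer chain on the oxygen, such as ethoxy, might keep it too, or might move back toward compound 2.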